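Changing the Group on a Ring Nitrogen: Expected Antiproliferative Effect

The compounds below may be only part of what the source reports. "The series", "measured", "known", "first", "only" and "open" are said of these compounds alone.

Compound 2 `Nc1ccccc1NC(=O)c1ccc(CSC(=S)N2CCN(c3cnccn3)CC2)cc1` and compound 1 `COc1ccc(N2CCN(C(=S)SCc3ccc(C(=O)Nc4ccccc4N)cc3)CC2)cc1` share a core and differ only in the group carried on an amine nitrogen in a ring. In a functional assay on A-375 cells (Homo sapiens) for antiproliferative activity, read by CCK-8 assay, with a stated time of 72 h, tested at 2 uM (on this read-out higher numbers stand for a stronger effect at the one concentration tested and lower numbers for a weaker effect), compound 2 gives 29.1%, and compound 1 gives 28.1%. For the measured compounds named here, the single measured step, a number 1 percentage points higher from compound 1 to compound 2 (within the scatter), lies within the scatter. Of the two numbers shown, compound 2 stands at the top, but compound 1 sits within the scatter of it, so no order between them can be claimed.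

Compound 3 `Nc1ccccc1NC(=O)c1ccc(CSC(=S)N2CCN(Cc3cccnc3)CC2)cc1` has not yet been measured. It differs from compound 2 by (pyridin-3-yl)methyl in place of pyrazin-2-yl on an amine nitrogen in a ring. Going by the values given here, this change sits at the same place as the only measured step, which also exchanged the group on that ring nitrogen and moved the read-out by a number 1 percentage points higher from compound 1 to compound 2 (within the scatter). One step is a thin basis, but it is the only one bearing on this position, and it gives no sign that such an exchange moves the read-out beyond the scatter. Compound 3 is therefore expected to show a step of a number 0.1 percentage points lower from compound 2 to compound 3 (within the scatter) in this assay, none beyond the scatter. The estimate for compound 3 is 29%, with a range from 15% to 45%.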

Compound 3, a percentage reported as inhibition, at one concentration (the size of the read-out at that concentration, not a potency): 31.5%
For compound 3 the middle estimate is 2.5 percentage points below the measured one; the measured number falls inside the stated range.
By their numbers in this assay, from the lowest: compounds 1, 2 and 3 (each within the scatter of the next).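

In this assay, exchanging pyrazin-2-yl for (pyridin-3-yl)methyl on the ring nitrogen gives a number 2.4 percentage points higher from compound 2 to compound 3 (within the scatter), and the wider exchange of 4-methoxyphenyl for the same group gives a number 3.4 percentage points higher from compound 1 to compound 3 (within the scatter). For the compounds shown here, the earlier pair held only groups with their aromatic ring attached straight to that nitrogen, so this is the first sign that a group with a carbon link before its ring also stays within the scatter of the others, and the read-out separates none of the three groups at this position. Nothing measured alongside these numbers accounts for how close they lie, and no other kind of data bears on them.

Still open, on these data alone, is whether any group on this ring nitrogen can move the read-out beyond the scatter, and a methyl group, a chain ending in a carboxylic acid, or a longer chain such as 2-(pyridin-3-yl)ethyl would each test that. As far as these compounds go, the read-out is also a size at one concentration and not a potency, and whether these compounds would stay this close across a range of concentrations remains unknown.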